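Adding a Second Chloro to a Purine Benzyl Series

This account rests on a few compounds, and the source may have more. Where it says the series, first, only, none or still open, it means among the compounds named here.

The series rests on a fused two-ring core carrying a benzyl group with a chloromethyl substituent. Compound 1 `ClCc1cccc(Cn2cnc3nc(Cl)nc(Cl)c32)c1` bears two chloro groups on the core and gives 2130 nM in a functional assay on HCT-15 cells (Homo sapiens) for cytotoxicity, read by sulforhodamine B assay, with a stated time of 48 h; on this read-out higher numbers stand for weaker inhibition of growth and lower numbers for stronger inhibition of growth. Compound 2 `ClCc1ccccc1Cn1cnc2c(Cl)ncnc21` carries a single chloro on the core and gives 4670 nM in this assay. Compound 3 `ClCc1ccc(Cn2cnc3ncnc(Cl)c32)cc1` has the single chloro on the core with the chloromethyl placed differently on the benzyl ring, but in this assay the result for compound 3 is "not determined" (no result reported), so it stands without a number.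

Compound 4 `ClCc1ccc(Cn2cnc3nc(Cl)nc(Cl)c32)cc1` differs from compound 3 by chloro in place of hydrogen on an aromatic carbon, on an aromatic carbon between two ring nitrogen atoms. Within the data shown here, no step between measured compounds describes this change, so the size of the step in this assay is unknown; the values of compound 1 and compound 2, which both carry this benzyl group in other arrangements, lie within the usual scatter of each other and suggest no step beyond the scatter. Compound 4 is expected to give about 2500 nM, in a range from 800 nM to 8000 nM.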

Compound 4, concentration for total growth inhibition: 3540 nM
Compound 4: the middle estimate sits 1.4-fold (0.15 log units) below what was measured, within the range that was stated.
By their numbers in this assay, from the lowest: compounds 1, 4 and 2 (each within the scatter of the next, the first and the last beyond it).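

Among these compounds, compound 3 has no number in this assay so no step from it to compound 4 can be read. No measured evidence bears on this result. The compounds shown leave open how the second chloro on the core affects growth inhibition.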